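The compounds below may be only part of what the source reports. "The series", "measured", "known", "first", "only" and "open" are said of these compounds alone.

Measured in an ADME assay on microsomes from liver (Homo sapiens) for metabolic stability, read by LC-MS, using NADPH, with a stated time of 30 min, tested at 1 uM; a lower number here means slower removal, a higher number faster removal of the compound:
Compound 1 `CC#Cc1cncc(-c2ccc3c(c2)[C@@]2(COC(N)=N2)c2cc(-c4ccnc(F)c4)ncc2O3)c1`: 40 mL.min-1.g-1
Compound 2 `Cc1cc2c(cn1)Oc1ccc(NC(=O)c3ccc(Cl)cn3)cc1[C@@]21COC(N)=N1`: 16 mL.min-1.g-1

Of these two measured compounds, compound 1 stands highest at 40 mL.min-1.g-1. Compound 2 gives the lower number, 16 mL.min-1.g-1, and the gap between them lies beyond the usual scatter. The two differ in more than one place, so their values offer no direct guide to a single exchange.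

Compound 3 `CC#Cc1cncc(-c2ccc3c(c2)[C@@]2(COC(N)=N2)c2cc(C4=CCCOC4)ncc2O3)c1` has not yet been measured. It keeps the core of compound 1 and changes one group: a group of 6 heavy atoms (5 carbon, 1 oxygen; one six-membered non-aromatic ring with 1 hetero atom) in place of a group of 7 heavy atoms (5 carbon, 1 nitrogen, 1 fluorine; one six-membered aromatic ring with 1 hetero atom), on an aromatic carbon. The 2-fluoropyridin-4-yl group leaves an aromatic carbon of a six-membered aromatic ring with 1 nitrogen, and a six-membered non-aromatic ring with 1 hetero atom enters there.

Among the compounds with values here, with no measured step for this exchange, only a small shift is expected, slightly downward and not beyond the scatter. The expected step is a 1.3-fold lower number from compound 1 to compound 3 (0.10 log units; within the scatter). For compound 3 the estimated value is 32 mL.min-1.g-1, with an expected range from 14 mL.min-1.g-1 to 75 mL.min-1.g-1.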

Compound 3, intrinsic clearance in microsomes: 76 mL.min-1.g-1
Compound 3: middle estimate off by 2.4-fold (0.38 log units), on the low side, outside the stated range (above it).
By their numbers in this assay, from the lowest: compound 2; then compounds 1 and 3 (each within the scatter of the next).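

In this assay, replacing the 2-fluoropyridin-4-yl group with the six-membered non-aromatic ring with 1 hetero atom, on the aromatic carbon next to the ring nitrogen, gives a 1.9-fold higher number from compound 1 to compound 3 (0.28 log units; within the scatter). Within the data shown here, this is the first single exchange that can be read, and it shows that at this place an aromatic ring with a nitrogen and a fluorine can give way to a non-aromatic ring with an oxygen and a double bond without a step that rises beyond the scatter. No measurement shown here accounts for the size of this step.

As far as these compounds go, whether any group on this carbon can give a step beyond the scatter remains open, for example a morpholine ring, a methoxy group or a primary amine in place of the ring in compound 3. From the compounds shown here alone, it is also open whether the same exchange would give a similar step on the core of compound 2, since one step on a single core cannot show how far it carries.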